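Fluoro in Place of Methyl on the Benzoyl Ring

The source may hold more compounds than are shown below. What is called first, only, known or untested is meant among the compounds shown, and "the series" means these compounds.

Measured compounds:
- compound 1, `COc1cccc(C(=O)c2ccc3c(ccn3S(=O)(=O)c3cccc(/C=C/C(=O)NO)c3)c2)c1`, 7740 nM
- compound 2, `Cc1ccc(C(=O)c2ccc3c(ccn3S(=O)(=O)c3cccc(/C=C/C(=O)NO)c3)c2)cc1`, 9100 nM

Of the compounds shown here, two have been tested in an assay on isolated protein for inhibition of polyamine deacetylase HDAC10 (Homo sapiens); on this read-out lower numbers stand for stronger inhibition and higher numbers for weaker inhibition. Compound 2 gives 9100 nM, the highest of the two numbers; its nearest neighbour is compound 1 with 7740 nM, and the step of a 1.2-fold higher number from compound 1 to compound 2 (0.07 log units; within the scatter) lies within the scatter, so the two values are not distinguished.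

Compound 3, `O=C(/C=C/c1cccc(S(=O)(=O)n2ccc3cc(C(=O)c4ccc(F)cc4)ccc32)c1)NO`, has not yet been measured. It differs from compound 2 by a single change: fluoro in place of methyl on an aromatic carbon.

Among the measured compounds shown here, only one measured step exists, the one from compound 1 to compound 2, which swapped 4-methylphenyl for 3-methoxyphenyl on the carbonyl carbon and produced no change beyond the scatter. It concerns a different exchange on the same aromatic ring and gives no direct reading on a fluoro for methyl swap, but it shows that this ring tolerates a change of substituent without a measurable shift. Compound 3 is therefore expected to stay close to compound 2, with a step of a 1.0-fold lower number from compound 2 to compound 3 (0.00 log units; within the scatter) that does not exceed the scatter. The estimate for compound 3 in this assay is 9000 nM, within a range from 4500 nM to 18000 nM.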

Compound 3, half-maximal inhibitory concentration: 5240 nM
The estimate for compound 3 lay 1.7-fold (0.23 log units) above the measured number; the measured number falls inside the stated range.
By their numbers in this assay, from the lowest: compounds 3, 1 and 2 (each within the scatter of the next).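

In this assay, the direct exchange of methyl for fluoro on an aromatic carbon para to a large group gives a 1.7-fold lower number from compound 2 to compound 3 (0.24 log units; within the scatter) and so does not separate the two groups at this position. Unlike the earlier step, this one changes only the group at that place, one heavy atom for another, which makes it the first direct reading of this exchange on the ring. The comparison of 4-fluorophenyl with 3-methoxyphenyl on the carbonyl carbon gives a 1.5-fold lower number from compound 1 to compound 3 (0.17 log units; within the scatter) as its result, so all three benzoyl variants remain undistinguished in this assay, and no evidence bearing on the result is available to account for it.

The compounds shown leave open whether a different kind of group at this place, such as an amine or a carboxylic acid, would move the number beyond the scatter. They also leave open whether any change on this ring can shift the value at all, or whether the numbers for this series are set by other parts of the shared core.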